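This account rests on a few compounds, and the source may have more. Where it says the series, first, only, none or still open, it means among the compounds named here.

Compound 1 `COc1ccc(N/C(CCNC2=CC(=O)c3ccccc3C2=O)=N\S(=O)(=O)c2ccc(C)cc2)c(OC)c1`: 67300 nM
Compound 2 `Cc1ccc(S(=O)(=O)/N=C(/CCNC2=CC(=O)c3ccccc3C2=O)Nc2ccc(Cl)cc2Cl)cc1`: 18600 nM

These two compounds were tested in a functional assay on DU-145 cells (Homo sapiens) for cytotoxicity, read by MTT assay, with a stated time of 48 h (on this read-out lower numbers stand for stronger inhibition and higher numbers for weaker inhibition), and compound 2 gives 18600 nM, the lower of the two numbers, while compound 1 gives 67300 nM. For the measured compounds named here, the one measured step, a 3.6-fold lower number from compound 1 to compound 2 (0.56 log units; beyond the scatter), came from exchanging the aryl group on the amine nitrogen.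

Compound 3 `Cc1ccc(S(=O)(=O)/N=C(/CCNC2=CC(=O)c3ccccc3C2=O)Nc2cc(F)c(F)c(F)c2)cc1` changes the same position again: 3,4,5-trifluorophenyl in place of 2,4-dichlorophenyl on an amine nitrogen. Going by the values given here, no measured step compares one halogen-bearing aryl group with another, so the only guide is the aryl swap already seen, which moved the number by a modest amount. A change of similar or smaller size is expected here, with no firm direction, and the step from compound 2 to compound 3 is estimated as a 1.3-fold higher number from compound 2 to compound 3 (0.13 log units; within the scatter). For compound 3 the expected value in this assay is therefore 25000 nM, within a range of 9000 nM to 70000 nM.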

Compound 3, half-maximal inhibitory concentration: 12600 nM
Compound 3: middle estimate off by 2.0-fold (0.30 log units), on the high side; the range from low to high includes it.
By their numbers in this assay, from the lowest: compounds 3 and 2 (each within the scatter of the next); then compound 1.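

In this assay, exchanging one halogen-bearing aryl group for another on the amine nitrogen gives a 1.5-fold lower number from compound 2 to compound 3 (0.17 log units; within the scatter) and so does not separate these two compounds. Set against the 2,4-dimethoxyphenyl group, the 3,4,5-trifluorophenyl group gives a 5.3-fold lower number from compound 1 to compound 3 (0.73 log units; beyond the scatter) and so, like the 2,4-dichlorophenyl group, stands clearly apart from compound 1 in these three compounds. Nothing available here explains why the numbers fall this way.

The compounds shown do not tell whether the kind of halogen or its place on the ring matters, which a comparison of 4-fluorophenyl with 4-chlorophenyl could test. They also leave open whether this position needs an aryl group at all, or whether a cyclohexyl or a simple methyl group would serve.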